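Cyclopentyl for 4-hydroxyphenyl on the shared core

This account rests on a few compounds, and the source may have more. Where it says the series, first, only, none or still open, it means among the compounds named here.

Three compounds on the shared core have numbers in an assay on Cortex for displacement of a labelled ligand from adenosine receptor A1 (Rattus norvegicus); a higher number here means a weaker inhibitor, a lower number a stronger inhibitor. Compound 1 `CCCn1c(=O)n(C)c(=O)c2[nH]c(-c3ccc(O)cc3)nc21` gives 2.54 nM in this assay, the lowest number of the three. Compound 2 `CCCn1c(=O)n(C)c(=O)c2[nH]c(-c3ccc(C#N)cc3)nc21` gives 13.9 nM, and compound 3 `CCCn1c(=O)c2nc(-c3ccncc3)[nH]c2n(C)c1=O` gives 27.6 nM; both sit beyond the scatter from compound 1. Among the compounds with values here, the one single-point step among them, a 5.5-fold higher number from compound 1 to compound 2 (0.74 log units; beyond the scatter), concerns cyano in place of hydroxy on an aromatic carbon and is modest in size. Compound 4 `CCCn1c(=O)n(C)c(=O)c2[nH]c(C3CCCC3)nc21` carries cyclopentyl in place of 4-hydroxyphenyl on an aromatic carbon. Within the data shown here, no measured step exchanges the aromatic ring itself for a non-aromatic one, so the step from compound 1 to compound 2 and the gap to compound 3 give only loose guidance; both say that changes at this part of the core have so far shifted the number by a moderate amount, in the direction of weaker binding. For compound 4 the expected value in this assay is 2.5 nM, between 0.5 nM and 15 nM. The expected step is therefore a 1.0-fold lower number from compound 1 to compound 4 (0.01 log units; within the scatter), with a range wide enough to admit a shift beyond the scatter in either direction.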

Compound 4, inhibition constant: 0.85 nM
The estimate for compound 4 lay 2.9-fold (0.47 log units) above the measured number; the measured number falls inside the stated range.
By their numbers in this assay, from the lowest: compound 4; then compound 1; then compounds 2 and 3 (each within the scatter of the next).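

In this assay, replacing the aromatic ring with a non-aromatic one gives a 3.0-fold lower number from compound 1 to compound 4 (0.48 log units; beyond the scatter), so a low number at this position, on an aromatic carbon between two ring nitrogen atoms, requires neither the six-membered aromatic ring nor the hydroxy group with its hydrogen-bond donor and acceptor. Within the data shown here, the only other single-point step at this position, a 5.5-fold higher number from compound 1 to compound 2 (0.74 log units; beyond the scatter), went the other way, so a change here can lower the number as well as raise it. Nothing on hand explains the direction of this step.

This one change removes the aromatic ring and the hydroxy group and alters the ring size all at once, so their separate contributions remain unresolved. Unsubstituted phenyl and cyclohexyl would help separate them, and an open butyl chain would test whether a ring is needed at all.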